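Cytotoxicity on rat L6 cells: from compound 2 to compound 4

The compounds below may be only part of what the source reports. "The series", "measured", "known", "first", "only" and "open" are said of these compounds alone.

Measured so far:
- compound 1, `CC1=CC(C)(C)N(Cc2ccc(C)cc2)c2ccc(O)cc21`: 8100 nM
- compound 2, `CC(=O)Oc1ccc2c(c1)C(C)=CC(C)(C)N2Cc1cccc(C#N)c1`: 31000 nM
- compound 3, `CC1=CC(C)(C)N(Cc2ccccc2)c2ccc(OC(=O)c3ccccc3)cc21`: limit, > 240000 nM

Of the compounds shown here, three sharing one core have been tested in an ADME assay on L6 cells (Rattus norvegicus) for cytotoxicity, read by resazurin assay, with a stated time of 70 h; a higher number here means a weaker inhibitor, a lower number a stronger inhibitor. Compound 1 gives 8100 nM. Compound 2 gives 31000 nM, the highest of the two numbers, so it is the weaker of the two in this assay. For compound 3 only a limit of the assay is known, > 240000 nM, which is a limit and not a number (the limit of > 240000 nM in this assay, at which 1 of the 3 values shown sits).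

The next compound, compound 4, `CC(=O)Oc1ccc2c(c1)C(C)=CC(C)(C)N2C`, differs from compound 2 in one place: hydrogen in place of 3-cyanophenyl on a saturated chain carbon bound to a nitrogen on an aromatic ring in a ring. Among the measured compounds shown here, no two measured compounds differ in exactly one place, so the size of this kind of step is not known from the data. Compound 4 is expected to give a somewhat higher number than compound 2, that is a weaker effect in this assay, with a step of a 1.9-fold higher number from compound 2 to compound 4 (0.29 log units; within the scatter) that may or may not go beyond the scatter. The estimate for compound 4 is 60000 nM, within 15000 nM to 240000 nM.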

Compound 4, half-maximal inhibitory concentration: 41000 nM
For compound 4 the middle estimate is 1.5-fold (0.17 log units) above the measured one; measured number inside the range.
By their numbers in this assay, from the lowest: compound 1; then compounds 2 and 4 (each within the scatter of the next). At a limit, above all of these: compound 3.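

In this assay, taking away the 3-cyanophenyl group and leaving hydrogen in its place gives a 1.3-fold higher number from compound 2 to compound 4 (0.12 log units; within the scatter) and offers the first direct view of a single change on this core. On a saturated chain carbon bound to a nitrogen on an aromatic ring in a ring, a group of 8 heavy atoms, including an aromatic ring and a nitrile, can therefore be lost without a difference that this measurement can separate from scatter. Nothing measured here gives a reason for this result.

The compounds shown leave open whether an ethyl group, a longer chain or a chain ending in an amine at this place would also stay within the scatter of compound 4 in this assay. They also leave open whether the same swap would behave alike on a core carrying a different group in place of the acetate.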